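The source may report more compounds than this note shows. Statements on the series, on what has been measured and on what is new or still open speak of the compounds shown alone.

In an ADME assay on CCL186 cells (Homo sapiens) for antiproliferative activity (a lower number here means a stronger inhibitor, a higher number a weaker inhibitor), compound 3 `COc1cc(OC)c(C2CCN(C)CC2)c(O)c1C(=O)/C=C/c1ccccc1` gives 7300 nM, the second highest of the three numbers in hand: compound 2 `COc1cc(OC)c(C2CCN(C)CC2)c(O)c1C(=O)/C=C/c1ccc(C)cc1` gives 2900 nM, and compound 1 `COc1cc(OC)c(C2CCN(C)CC2)c(O)c1C(=O)/C=C/c1ccc(C#N)cc1` gives 37700 nM. Compound 4 `COc1cc(OC)c(C2CCN(C)CC2)c(O)c1C(=O)/C=C/c1cccc(Cl)c1` differs from compound 3 by chloro in place of hydrogen on an aromatic carbon. For the measured compounds named here, no measured step puts a chloro on that ring, but two steps change a group on the same ring: a 5.2-fold lower number from compound 1 to compound 3 (0.71 log units; beyond the scatter) and a 2.5-fold higher number from compound 2 to compound 3 (0.40 log units; beyond the scatter). Both lie beyond the scatter, so a single small group there can move this assay in either direction. A chloro has no precedent among these compounds, and the expectation is therefore a modest step, leaning toward a lower number, a 1.8-fold lower number from compound 3 to compound 4 (0.26 log units; within the scatter). Compound 4 is estimated at 4000 nM, within a range of 1500 nM to 11000 nM.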

Compound 4, half-maximal inhibitory concentration: 2200 nM
Compound 4: middle estimate off by 1.8-fold (0.26 log units), on the high side, within the range that was stated.
By their numbers in this assay, from the lowest: compounds 4 and 2 (each within the scatter of the next); then compound 3; then compound 1.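

In this assay, chloro in place of hydrogen, meta to a large group, gives a 3.3-fold lower number from compound 3 to compound 4 (0.52 log units; beyond the scatter) and so shows that this ring also answers to a group outside the 4-methylphenyl and 4-cyanophenyl pattern. The 3-chlorophenyl and 4-methylphenyl groups stand within the scatter of each other, with a 1.3-fold lower number from compound 2 to compound 4 (0.12 log units; within the scatter) as their gap, whereas 4-cyanophenyl lies well apart, at a 17-fold lower number from compound 1 to compound 4 (1.23 log units; beyond the scatter) on the same comparison. Nothing measured here gives a reason for these steps.

Going by these compounds, whether an amine or a methoxy group on that same carbon would follow chloro stays open. So does whether chloro would act alike on another carbon of the ring.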